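Furan to Thiophene on a Chalcone-Type Topoisomerase Inhibitor

The compounds below may be only part of what the source reports. "The series", "measured", "known", "first", "only" and "open" are said of these compounds alone.

Measured compounds:
compound 1, `O=C(/C=C/c1ccco1)c1cccc(OCC2CO2)c1`, 28.5%
compound 2, `O=C(/C=C/c1ccco1)c1ccc(OCC2CO2)cc1`, 36.8%

In an assay for inhibition of DNA topoisomerase 1 (Homo sapiens), with a stated time of 30 min, tested at 100 uM (a higher number here means a stronger effect of the compound at the concentration tested, a lower number a weaker effect), compound 2 gives 36.8%, the highest of the two numbers measured. The nearest is compound 1, which in this assay gives 28.5%, a value within the usual scatter of that of compound 2, so the two are not distinguishable.

The unmeasured compound 3, `O=C(/C=C/c1cccs1)c1ccc(OCC2CO2)cc1`, differs from compound 2 in one place: thiophen-2-yl in place of furan-2-yl on a double-bonded chain carbon bound to a double-bonded chain carbon. For the measured compounds named here, no step between two measured compounds covers this kind of exchange, so nothing in the measured data points to a direction. Compound 3 is therefore expected to give a number close to that of compound 2, with the step of a number 1.2 percentage points higher from compound 2 to compound 3 (within the scatter) lying within the scatter rather than beyond it. The estimate for compound 3 in this assay is 38%, with a range from 20% to 58%.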

Compound 3, a percentage reported as inhibition, at one concentration (the size of the read-out at that concentration, not a potency): 0%
Compound 3: middle estimate off by 38 percentage points, on the high side; measured number outside the range, below it.
By their numbers in this assay, from the lowest: compound 3; then compounds 1 and 2 (each within the scatter of the next).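

In this assay, thiophen-2-yl in place of furan-2-yl on a double-bonded chain carbon bound to a double-bonded chain carbon gives a number 36.8 percentage points lower from compound 2 to compound 3 (beyond the scatter) and so shows that this position separates two rings with the same heavy-atom count, the same ring size and the same hydrogen-bond counts, one holding oxygen and the other sulfur. Compound 1 and compound 2 both carry furan-2-yl, so they could show nothing of this. No measurement shown explains why the exchange has so large an effect.

The compounds shown do not tell how a phenyl or pyrrol-2-yl group would read at this place. They also leave open whether the same exchange on the core of compound 1 would give a step of similar size.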